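Cytotoxicity series: benzyl variation on the shared core

The source may hold more compounds than are shown below. What is called first, only, known or untested is meant among the compounds shown, and "the series" means these compounds.

Compound 3 `O=C1c2ccccc2N(Cc2ccc(Cl)cc2)S(=O)(=O)N1Cc1ccccc1` carries chloro on an aromatic carbon of the benzyl group on the sulfonamide nitrogen in the ring; in a functional assay on MRC5 cells (Homo sapiens) (on this read-out higher numbers stand for lower toxicity in this test and lower numbers for higher toxicity in this test), compound 3 gives 60000 nM. Among the two numbers shown it stands highest, with compound 1 `O=C1c2ccccc2N(Cc2ccc(C(F)(F)F)cc2)S(=O)(=O)N1Cc1ccccc1` nearest: in this assay compound 1 gives 56000 nM, and the step of a 1.1-fold higher number from compound 1 to compound 3 (0.03 log units; within the scatter) stays within the scatter. Compound 2 `O=C1c2ccccc2N(Cc2ccc([N+](=O)[O-])cc2)S(=O)(=O)N1Cc1ccccc1` is reported in this assay only as a limit, > 59000 nM (the limit of > 59000 nM in this assay, at which 1 of the 3 values shown sits). The step of an at least 1.0-fold higher number from compound 1 to compound 2 (0.02 log units; that floor lies within the scatter) sits at a floor within the scatter, and the step that the limit leaves unreadable from compound 2 to compound 3 remains unreadable.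

Compound 4 `O=C1c2ccccc2N(Cc2cccc3ccccc23)S(=O)(=O)N1Cc1ccccc1` has not been measured. Its change from compound 3 is naphthalen-1-yl in place of 4-chlorophenyl on a saturated chain carbon bound to a sulfonamide nitrogen in a ring. Among the measured compounds shown here, no measured step exchanges one aromatic ring system for another; the steps seen so far, a 1.1-fold higher number from compound 1 to compound 3 (0.03 log units; within the scatter) and an at least 1.0-fold higher number from compound 1 to compound 2 (0.02 log units; that floor lies within the scatter), only swap substituents on an aromatic carbon and show nothing beyond the scatter. The step of a 1.1-fold lower number from compound 3 to compound 4 (0.04 log units; within the scatter) is expected to stay within the scatter. The estimate for compound 4 in this assay is 55000 nM, expected to fall between 25000 nM and 80000 nM.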

Compound 4, half-maximal cytotoxic concentration: > 58000 nM
Compound 4: no number, only a limit; the forecaster's own chance of this, stated with the estimate: 40%; at least 1.0-fold (0.02 log units) between middle value and limit.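

The place on a saturated chain carbon bound to a sulfonamide nitrogen in a ring now accepts naphthalen-1-yl, with 2 six-membered aromatic rings, in place of a single substituted phenyl, and in this assay compound 4 is reported only as a limit: the limit of > 58000 nM in this assay, at which 1 of the 4 values shown sits. Among the compounds shown here, the only readable step is an at least 1.0-fold higher number from compound 1 to compound 4 (0.01 log units; that floor lies within the scatter), so a change of the whole aromatic ring system, not just a substituent swap, gives no lower number here. The steps to compound 4 from compound 2 and compound 3 cannot be read.

Going by these compounds, how far the numbers of compound 2 and compound 4 run remains open, since both are limits. Also open, on these data alone, is whether an amine or a carboxylic acid on the aromatic ring at this place would lower the number.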